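The source may hold more compounds than are shown below. What is called first, only, known or untested is meant among the compounds shown, and "the series" means these compounds.

Measured so far, in a functional assay on the whole organism (strain Wistar) for inhibition, with Rattus norvegicus as the target, read by paw edema, with stated times of 60 min and 24 h, at a dose of 100 mg/kg by the oral route; on this read-out lower numbers stand for less inhibition and higher numbers for more inhibition at the one dose given (going by the name of the read-out):

compound 1 `COc1cc2c(cc1OC)C(CC(=O)O)CC2`: 26.7%
compound 2 `CCCCCCNC(=O)CC1CCc2cc(OC)c(OC)cc21`: 45.5%
compound 3 `COc1cc2c(cc1OC)C(CC(=O)NCc1ccccc1)CC2`: 43.3%

Compound 3 stands second highest of the three numbers. Its nearest neighbour is compound 2, a gap that lies within the scatter (a number 2.2 percentage points lower from compound 2 to compound 3 (within the scatter)); its furthest is compound 1, a gap beyond the scatter (a number 16.6 percentage points higher from compound 1 to compound 3 (beyond the scatter)). The next compound is compound 4 `COc1cc2c(cc1OC)C(CC(=O)N1CCNCC1)CC2`, which differs from compound 3 in one place: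

piperazin-1-yl in place of benzylamino on a carbonyl carbon

Among the compounds with values here, the steps that bear on this change are the two that replace the hydroxy on the carbonyl carbon with an amine, a number 18.8 percentage points higher from compound 1 to compound 2 (beyond the scatter) and a number 16.6 percentage points higher from compound 1 to compound 3 (beyond the scatter), both modest rises, and the swap between the two amides, a number 2.2 percentage points lower from compound 2 to compound 3 (within the scatter), which stays within the scatter. Within the data shown here, compound 4 keeps the amide carbonyl, so the gain over the acid seen in compound 2 and compound 3 is expected to be retained; no measured step exchanges a chain-bound amine for a ring-bound one, so the size of any further shift is unknown. For compound 4 a step of about a number 3.3 percentage points lower from compound 3 to compound 4 (within the scatter) is expected, that is, none beyond the scatter. Compound 4 is therefore estimated at 40%, with a range from 25% to 55%.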

Compound 4, a percentage reported as inhibition, in the whole organism at one dose (the size of the read-out at that dose, not a potency): 65%
Compound 4: middle estimate off by 25 percentage points, on the low side; measured number above the stated range.
By their numbers in this assay, from the lowest: compound 1; then compounds 3 and 2 (each within the scatter of the next); then compound 4.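

On the carbonyl carbon, the choice of amine now matters in this assay: hexylamino and benzylamino lie within the scatter of each other, whereas piperazin-1-yl stands clear of both (a number 21.7 percentage points higher from compound 3 to compound 4 (beyond the scatter); a number 19.5 percentage points higher from compound 2 to compound 4 (beyond the scatter)). The gain over the acid is therefore not a single level shared by all amides, and replacing hydroxy with piperazin-1-yl gives a large step (a number 38.3 percentage points higher from compound 1 to compound 4 (beyond the scatter)). No measurement available here accounts for the rise on exchanging benzylamino, with its six-membered aromatic ring of carbon only, for a six-membered non-aromatic ring with 2 hetero atoms.

From the compounds shown here alone, it remains open whether the rise depends on the second ring nitrogen, a question that morpholin-4-yl or piperidin-1-yl on the same carbonyl carbon would address. 4-Methylpiperazin-1-yl would show whether that nitrogen's hydrogen matters, and an open-chain 2-aminoethylamino group whether the ring itself is needed.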